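Isopropoxy for isopropyl on the carbonyl carbon

The compounds below may be only part of what the source reports. "The series", "measured", "known", "first", "only" and "open" are said of these compounds alone.

Compound 1 `CC(C)C(=O)OCOC(=O)C1=C(S[C@@H]2CN[C@H](C(=O)Nc3cccc(C(=O)O)c3)C2)[C@H](C)[C@@H]2[C@@H]([C@@H](C)O)C(=O)N12` was run in an ADME assay on a cell-free system (plasma, Homo sapiens) for metabolic stability, read by LC-MS, with a stated time of 60 min, at 37 degrees C, tested at 50 uM (on this read-out higher numbers stand for a more stable compound and lower numbers for a less stable compound), and compound 1 gives 15%. Among the three numbers compound 1 stands second highest: compound 3 `Cc1oc(=O)oc1COC(=O)N1C[C@@H]2C[C@H]1C(=O)Nc1cccc(c1)C(=O)OC/C=C\COC(=O)C1=C(S2)[C@H](C)[C@@H]2[C@@H]([C@@H](C)O)C(=O)N12` gives 20%, and compound 2 `CC(C)C(=O)OCOC(=O)C1=C(S[C@@H]2CN[C@H](C(=O)Nc3cccc(C(=O)OCOC(=O)C(C)C)c3)C2)[C@H](C)[C@@H]2[C@@H]([C@@H](C)O)C(=O)N12` gives 8%, both within the scatter of compound 1. Among the measured compounds shown here, the one step with a single change, a number 7 percentage points lower from compound 1 to compound 2 (within the scatter), lies within the scatter as well. Compound 4 `CC(C)OC(=O)OCOC(=O)C1=C(S[C@@H]2CN[C@H](C(=O)Nc3cccc(C(=O)O)c3)C2)[C@H](C)[C@@H]2[C@@H]([C@@H](C)O)C(=O)N12` differs from compound 1 by isopropoxy in place of isopropyl on a carbonyl carbon. For the measured compounds named here, no measured step touches this change, and the only step in hand is small, so a step no larger than the scatter is expected, no change at the digits printed from compound 1 to compound 4 (within the scatter). Compound 4 is therefore estimated at 15%, with a range from 5% to 30%.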

Compound 4, percent of the compound remaining: 62%
For compound 4 the middle estimate is 47 percentage points below the measured one; measured number above the stated range.
By their numbers in this assay, from the lowest: compounds 2, 1 and 3 (each within the scatter of the next, the first and the last beyond it); then compound 4.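

Isopropoxy in place of isopropyl on a carbonyl carbon gives a number 47 percentage points higher from compound 1 to compound 4 (beyond the scatter) in this assay. The entering group adds one oxygen to the leaving group, so the read-out at this position responds to a small change in the group on this carbonyl carbon. Among the compounds shown here, the only other single change, at the carboxylic acid of compound 1, gives a number 7 percentage points lower from compound 1 to compound 2 (within the scatter) and stays small.

Open, going by these compounds, is whether a longer chain or an amine on this carbonyl carbon would hold the higher number. No measurement at hand bears on the reason for the step.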